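The source may hold more compounds than are shown below. What is called first, only, known or untested is meant among the compounds shown, and "the series" means these compounds.

Compound 1, `COc1cc(C)cc(-c2c(-c3ccnc(-c4ccc(C(C)=O)cc4)c3)cnn2CC#N)c1`, is tested in a functional assay on UACC-62 cells (Homo sapiens) for cytotoxicity, read by sulforhodamine B assay, with a stated time of 48 h, tested at 100 nM (on this read-out higher numbers stand for a weaker effect at the one concentration tested and lower numbers for a stronger effect), where compound 1 gives 89%. Among the three compounds measured this way it stands highest: compound 3, `Cc1cc(O)cc(-c2nn(CC#N)cc2-c2ccnc(-c3ccc(N(C)C)cc3)c2)c1`, is nearest with 87%, a gap within the scatter, and compound 2, `COc1cc(C)cc(-c2nn(CC#N)cc2-c2ccnc(-c3ccc(N(C)C)cc3)c2)c1`, lies furthest with 18%, a gap beyond it. For the measured compounds named here, the one single-point change measured so far, a number 69 percentage points higher from compound 2 to compound 3 (beyond the scatter), concerns hydrogen in place of methyl on an oxygen on an aromatic ring and does not touch the position altered here.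

Compound 4, `COc1cc(C)cc(-c2c(-c3ccnc(-c4ccc(N(C)C)cc4)c3)cnn2CC#N)c1`, differs from compound 1 in one place: dimethylamino in place of acetyl on an aromatic carbon. Going by the values given here, no measured step covers dimethylamino in place of acetyl directly. What can be said is that compound 2, which carries the dimethylamino group on its own arrangement of the shared core, gives 18%, while compound 1 gives 89%; the two differ elsewhere as well, so this is a hint rather than a step. On that hint a drop in this assay is expected for compound 4, though with wide uncertainty. The expected step is a number 49 percentage points lower from compound 1 to compound 4 (beyond the scatter). Compound 4 is therefore estimated at 40%, within a range of 10% to 85%.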

Compound 4, a percentage reported as activity, at one concentration (the size of the read-out at that concentration, not a potency): 37%
Estimate against measurement, compound 4: 3 percentage points above, and the stated range covers the measured number.
By their numbers in this assay, from the lowest: compound 2; then compound 4; then compounds 3 and 1 (each within the scatter of the next).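

In this assay, putting dimethylamino in place of acetyl on an aromatic carbon, para to a large group, gives a number 52 percentage points lower from compound 1 to compound 4 (beyond the scatter) and is a large change. For the compounds shown here, this is the first direct reading at this position, and it shows that the aryl group's substituent alone can shift the read-out well beyond the scatter on the core of compound 1. The two groups have equal counts of heavy atoms, hydrogen-bond donors and hydrogen-bond acceptors, so those counts do not separate them, and nothing given here explains the step.

As far as these compounds go, with only acetyl and dimethylamino compared at this position, it remains open whether the effect is specific to dimethylamino or would also appear with a primary amine, a methoxy group, a carboxylic acid or the longer diethylamino group. From the compounds shown here alone, it is also open whether hydrogen in place of methyl on an oxygen on an aromatic ring, which gave a number 69 percentage points higher from compound 2 to compound 3 (beyond the scatter) on the other arrangement of the shared core, would have a comparable effect on compound 4.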